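Methoxy removal on the aryl ring of the pyrrolyl enone series

A few compounds are considered here, and "the series" means these few. Any claim that something is new, unique, unknown or untested is made for them only; others in the source may bear on it.

The series shares the cinnamoyl-pyrrole core of compound 1 `O=C(/C=C/c1ccccc1F)c1ccc[nH]1`, which in an assay for inhibition of cytochrome P450 1A1 (Homo sapiens), read by fluorescence, using microsomes, with a stated time of 10 min (on this read-out lower numbers stand for stronger inhibition and higher numbers for weaker inhibition), gives > 20000 nM; this figure is a limit of the assay rather than a number. Going by the values given here, compound 2 `COc1cccc(/C=C/C(=O)c2ccc[nH]2)c1OC` carries two methoxy groups on the phenyl ring and in this assay gives 5200 nM, the only measured number so far. The other value, that of compound 1, is a limit (the limit of > 20000 nM in this assay, at which 1 of the 2 values shown sits). Compound 3 `COc1ccccc1/C=C/C(=O)c1ccc[nH]1` is the analogue with one methoxy group fewer: hydrogen in place of methoxy on an aromatic carbon, ortho to the remaining methoxy group and meta to the group of 9 heavy atoms.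

Among the compounds with values here, no step between measured compounds is available to calibrate this change. Within the data shown here, the single remaining methoxy group is kept, so compound 3 is expected to stay within reach of compound 2 rather than fall back to the limit seen for compound 1. A modest loss beyond the usual scatter is the working expectation, a 1.7-fold higher number from compound 2 to compound 3 (0.24 log units; within the scatter). Compound 3 is accordingly estimated at 9000 nM, with a range from 3000 nM to 25000 nM.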

Compound 3, half-maximal inhibitory concentration: 900 nM
Estimate against measurement, compound 3: 10-fold (1.00 log units) above, outside the stated range (below it).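

In this assay, going by these compounds alone, the methoxy group ortho to the remaining methoxy group and meta to the group of 9 heavy atoms turns out to be a liability rather than a support: hydrogen in its place gives a 5.8-fold lower number from compound 2 to compound 3 (0.76 log units; beyond the scatter), so the stronger inhibition belongs to the compound with the single methoxy group. With that methoxy group kept, the exchange of fluoro for methoxy gives an at least 22-fold lower number from compound 1 to compound 3 (1.34 log units; beyond the scatter), the first sign in the series that the choice of substituent on this aromatic ring can separate a compound with a measured number from one without. The size of that second step is only a bound, as the value of compound 1 is a limit and not a number: the limit of > 20000 nM in this assay, at which 1 of the 3 values shown sits.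

The compounds shown leave open whether the gain seen with the single methoxy group is particular to methoxy, or would also appear with an ethoxy group, a hydroxy group or an amine in its place. They also leave open how a fully unsubstituted phenyl ring would compare, with hydrogen in place of the last methoxy group on the shared core.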